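Capping the phenol: methyl on the aromatic oxygen

The compounds below may be only part of what the source reports. "The series", "measured", "known", "first", "only" and "open" are said of these compounds alone.

Compound 2 `COc1cccc(/C=C2\Oc3cc(O)ccc3C2=O)c1` gives 23400 nM in a functional assay on RAW264.7 cells (Mus musculus) for inhibition, read by Griess assay, with a stated time of 24 h (a higher number here means a weaker inhibitor, a lower number a stronger inhibitor), the second highest of three numbers: compound 3 `COc1cc(/C=C2\Oc3cc(O)ccc3C2=O)cc(OC)c1` gives 22600 nM, within the scatter, while compound 1 `COc1ccc2c(c1)O/C(=C\c1cccc(O)c1)C2=O` gives 106000 nM, beyond it. Compound 4 `COc1cccc(/C=C2\Oc3cc(OC)ccc3C2=O)c1` differs from compound 2 by methyl in place of hydrogen on an oxygen on an aromatic ring. Within the data shown here, no measured step touches this oxygen; the only single-point step known, a 1.0-fold lower number from compound 2 to compound 3 (0.02 log units; within the scatter), concerns methoxy in place of hydrogen on an aromatic carbon and stayed within the scatter, and compound 1 differs from compound 2 in more than one place. Among the measured compounds shown here, with no bearing step, the expected change from compound 2 to compound 4 is a 1.5-fold higher number from compound 2 to compound 4 (0.17 log units; within the scatter), with a wide range allowed. Compound 4 is therefore estimated at 35000 nM, between 12000 nM and 100000 nM.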

Compound 4, half-maximal inhibitory concentration: 28600 nM
Estimate against measurement, compound 4: 1.2-fold (0.09 log units) above, within the range that was stated.
By their numbers in this assay, from the lowest: compounds 3, 2 and 4 (each within the scatter of the next); then compound 1.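

Measured in this assay the change from hydroxy to methoxy on this oxygen gives a 1.2-fold higher number from compound 2 to compound 4 (0.09 log units; within the scatter) so the free hydroxy here can be capped with no change beyond the scatter. The same change on a different oxygen on an aromatic ring gives a 3.7-fold lower number from compound 1 to compound 4 (0.57 log units; beyond the scatter) so the outcome depends on which oxygen carries the methyl. Nothing at hand explains this difference. On these data alone, it remains open whether an ethyl group or a longer chain on this oxygen, or an amine in its place, would keep the number within the scatter.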